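Aryl exchange on compound 2: working notes

The source may report more compounds than this note shows. Statements on the series, on what has been measured and on what is new or still open speak of the compounds shown alone.

In a functional assay on KBVIN cells (Homo sapiens) for antiproliferative activity, read by sulforhodamine B assay, with a stated time of 3 days (on this read-out lower numbers stand for an effect already at smaller amounts and higher numbers for an effect only at larger amounts of compound), compound 1 `CCC1=C(O)c2c(oc(-c3ccc(F)cc3)cc2=O)C(CC)(CC)C1=O` gives 1.85 uM and compound 2 `CCC1=C(O)c2c(oc(-c3cc(C)cc(C)c3)cc2=O)C(CC)(CC)C1=O` gives 0.45 uM as the lower of the two numbers. Compound 3 `CCC1=C(O)c2c(oc(-c3ccc(F)c(C)c3)cc2=O)C(CC)(CC)C1=O` carries 4-fluoro-3-methylphenyl in place of 3,5-dimethylphenyl on an aromatic carbon, with 4-fluoro-3-methylphenyl in place of 3,5-dimethylphenyl on an aromatic carbon as the counted difference. Among the measured compounds shown here, the one measured step bearing on this is a 4.1-fold lower number from compound 1 to compound 2 (0.61 log units; beyond the scatter) for 3,5-dimethylphenyl in place of 4-fluorophenyl, and the entering group shares features with both groups, so part of that step is expected to come back as a higher number in this assay than for compound 2. The estimate is a 1.8-fold higher number from compound 2 to compound 3 (0.25 log units; within the scatter) as the size of the step. Compound 3 is expected at 0.8 uM within an estimated range of 0.35 uM to 1.8 uM in this series.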

Compound 3, concentration for half-maximal effect: 1.62 uM
Compound 3: the middle estimate sits 2.0-fold (0.31 log units) below what was measured; the range from low to high includes it.
By their numbers in this assay, from the lowest: compound 2; then compounds 3 and 1 (each within the scatter of the next).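

At this position, 4-fluoro-3-methylphenyl does not keep the low number of 3,5-dimethylphenyl in this assay, giving a 3.6-fold higher number from compound 2 to compound 3 (0.56 log units; beyond the scatter). Methyl in place of hydrogen on the 4-fluorophenyl ring gives a 1.1-fold lower number from compound 1 to compound 3 (0.06 log units; within the scatter), so among these three compounds only the 3,5-dimethylphenyl group stands apart. No measured evidence on the compounds bears on this difference.

The step from compound 2 to compound 3 alters two ring positions at once, so the share of each stays unresolved. A 3-methylphenyl or 4-fluoro-3,5-dimethylphenyl group would separate the two changes.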